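Replacing a Carbocyclic Ring with a Sulfur-Containing One

The compounds below may be only part of what the source reports. "The series", "measured", "known", "first", "only" and "open" are said of these compounds alone.

Compound 1 `CC(C)(C)C#Cc1cc(-c2ccc(/C=C/C(=O)O)cc2Cl)ccc1O` in a functional assay on AML cells (Homo sapiens) for antiproliferative activity, read by MTT assay, with a stated time of 48 h (on this read-out higher numbers stand for weaker inhibition and lower numbers for stronger inhibition), gives only a limit of the assay, > 5000 nM.
Compound 2 `Cc1cccc(C)c1-c1cc(-c2ccc(/C=C/C(=O)O)cc2Cl)ccc1O` in this assay gives only a limit, > 5000 nM.
Compound 3 `CC1(c2cc(-c3ccc(/C=C/C(=O)O)cc3Cl)ccc2O)CCCCC1` in this assay gives only a limit, > 5000 nM.

None of the three values is a true number: the limit of > 5000 nM in this assay, at which 3 of the 3 values shown sit. Compound 3 therefore stands exactly where the other two stand, at the limit, and no ordering among the three is possible. The measured steps are a step that the two limits leave unreadable from compound 1 to compound 2, a step that the two limits leave unreadable from compound 1 to compound 3 and a step that the two limits leave unreadable from compound 2 to compound 3; not one of them has a readable size.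

Compound 4 `CC1(c2cc(-c3ccc(/C=C/C(=O)O)cc3Cl)ccc2O)SCCCS1` differs from compound 3 by a group of 7 heavy atoms (5 carbon, 2 sulfur; one six-membered non-aromatic ring with 2 hetero atoms) in place of a group of 7 heavy atoms (7 carbon; one six-membered non-aromatic ring of carbon only), on an aromatic carbon, on a carbon that is ortho to a hydroxy group and meta to a large group. Among the compounds with values here, all three measured steps touch this same position, yet since each is unreadable, they offer neither a size nor a direction; what is known is only that compound 3 sits at the limit. For compound 4 the step expected is a step that the limit leaves unreadable from compound 3 to compound 4, with a further limit the most probable outcome. Compound 4 is accordingly estimated at 6000 nM, within a range from 1500 nM to 20000 nM.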

Compound 4, half-maximal inhibitory concentration: > 5000 nM
Compound 4: only a limit was reported; the forecaster's own chance of this, stated with the estimate: 70%; the middle value does not contradict the limit.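

In this assay compound 4 gives only a limit, > 5000 nM. The steps to compound 4 from compound 1, compound 2 and compound 3 therefore cannot be read, because no true number exists on either side: the limit of > 5000 nM in this assay, at which 4 of the 4 values shown sit. The compounds shown leave open how these four groups rank against one another, and whether any of them allows a measurable value.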